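Working notes: opening the ring of compound 2

A few compounds are considered here, and "the series" means these few. Any claim that something is new, unique, unknown or untested is made for them only; others in the source may bear on it.

Of the compounds shown here, three have been read so far in a functional assay on HO8910 cells (Homo sapiens) for inhibition, read by MTT assay, with a stated time of 24 h, tested at 0.1 ug/mL; a lower number here means less inhibition of growth, a higher number more inhibition of growth at the concentration tested. Among the compounds with values here, compound 2 `O=C(CCCCC1CCSS1)Nc1ccccc1Cl` gives 8.17%, the only number in the set. Compound 1 `CC(=O)SCCC(CCCCC(=O)O)SC(C)=O` is reported as "not active" (no number reported), and compound 3 `O=C(CCCCC1CCSS1)Nc1ccc(Cl)cn1` is reported as "not active" (no number reported). Compound 2 therefore stands alone as a numeric reading, with no second number to scale it against.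

The next compound is compound 4 `O=C(CCCCC(S)CCS)Nc1ccccc1Cl`, which differs from compound 2 in one place: a group of 5 heavy atoms (3 carbon, 2 sulfur; no ring) in place of a group of 5 heavy atoms (3 carbon, 2 sulfur; one five-membered non-aromatic ring with 2 hetero atoms), on a saturated chain carbon, four bonds along the chain from a carbonyl carbon. Within the data shown here, no measured pair isolates this change, so the step in this assay has no direct precedent. Compound 1 also carries no ring at that place and gives "not active" (no number reported), but it differs from compound 4 elsewhere as well, so it fixes no step size. The working expectation rests on compound 2 at 8.17% and is for no step beyond the usual scatter, in either direction. A report without a number also remains possible. The estimated a number 0.8 percentage points higher from compound 2 to compound 4 (within the scatter) is expected to stay within that scatter. Compound 4 is expected at 9%, with an estimated range of 2% to 22%.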

Compound 4, percent growth inhibition at one concentration: 6.11%
Estimate against measurement, compound 4: 2.9 percentage points above, within the range that was stated.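

In this assay the series now has its first readable step, a number 2.1 percentage points lower from compound 2 to compound 4 (within the scatter), and it lies within the usual scatter. At this place, on a saturated chain carbon, four bonds along the chain from a carbonyl carbon, the open 1,3-disulfanylpropyl group with its 2 hydrogen-bond donors cannot be told apart from the five-membered non-aromatic ring with 0 hydrogen-bond donors, so opening the ring does not by itself cost compound 4 its numeric reading at the single concentration tested. No measurement at hand explains this outcome or bears on it.

Still open, as far as these compounds go, is whether capping both sulfur atoms of compound 4 as thioacetates, or replacing them with primary amines, would give a step beyond the scatter while the rest of compound 4 stays the same. Also open, from the compounds shown here alone, is whether the open and ring forms would still read alike with a longer chain between the carbonyl carbon and this place, where a single step could then be compared with the present one.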